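Methylating the amide nitrogen of a sulfoxide series

This account rests on a few compounds, and the source may have more. Where it says the series, first, only, none or still open, it means among the compounds named here.

Of the compounds shown here, three sharing one core have been measured in an assay on isolated protein for inhibition of sodium-dependent dopamine transporter (Rattus norvegicus), read by radioligand binding; a higher number here means a weaker inhibitor, a lower number a stronger inhibitor. Compound 1 `COC(=O)C[S+]([O-])CC1CN(C)CCC1c1ccc(Cl)cc1` gives 231 nM. Compound 2 `CN1CCC(c2ccc(Cl)cc2)C(C[S+]([O-])CC(=O)NO)C1` gives 55 nM. Compound 3 `CNC(=O)C[S+]([O-])CC1CN(C)CCC1c1ccc(Cl)cc1` gives 164 nM, the second highest of the three numbers; the step of a 1.4-fold lower number from compound 1 to compound 3 (0.15 log units; within the scatter) stays within the scatter, while the step of a 3.0-fold higher number from compound 2 to compound 3 (0.47 log units; beyond the scatter) lies beyond it.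

Compound 4 `CN1CCC(c2ccc(Cl)cc2)C(C[S+]([O-])CC(=O)N(C)C)C1` differs from compound 3 by methyl in place of hydrogen on an amide-type nitrogen. Within the data shown here, two measured steps bear on this change. The step of a 1.4-fold lower number from compound 1 to compound 3 (0.15 log units; within the scatter), where the group on the carbonyl carbon changes, shows little movement. The step of a 3.0-fold higher number from compound 2 to compound 3 (0.47 log units; beyond the scatter), a change on the same amide-type nitrogen, is modest but real, in the direction of a higher number. Taken together, a further change on that nitrogen is expected to move the number by no more than a modest amount, if at all, and more likely upward than downward.

Compound 4 is therefore expected to give 260 nM, with a range from 100 nM to 650 nM. This estimated change, a 1.6-fold higher number from compound 3 to compound 4 (0.20 log units; within the scatter), would be near the edge of the scatter.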

Compound 4, inhibition constant: 2880 nM
Estimate against measurement, compound 4: 11-fold (1.04 log units) below; the whole stated range lies below it.
By their numbers in this assay, from the lowest: compound 2; then compounds 3 and 1 (each within the scatter of the next); then compound 4.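

In this assay, adding the second methyl to the amide-type nitrogen is far from a neutral change: it gives an 18-fold higher number from compound 3 to compound 4 (1.24 log units; beyond the scatter), a much larger step than the earlier change on that nitrogen, a 3.0-fold higher number from compound 2 to compound 3 (0.47 log units; beyond the scatter). The dimethylamino group also stands well apart from the other two groups on the carbonyl carbon, with a 52-fold higher number from compound 2 to compound 4 (1.72 log units; beyond the scatter) and a 12-fold higher number from compound 1 to compound 4 (1.10 log units; beyond the scatter); since the methoxy group of compound 1 also lacks the amide hydrogen, the loss of that hydrogen alone does not track the number. Nothing measured here accounts for this jump.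

The compounds shown leave open whether diethylamino on the carbonyl carbon would raise the number further, or whether plain amino would stay close to methylamino. They also leave open how a carboxylic acid at this carbonyl carbon would compare.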